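A few compounds are considered here, and "the series" means these few. Any claim that something is new, unique, unknown or untested is made for them only; others in the source may bear on it.

The measured compounds:
compound 1, `Cc1cc(-c2ccccc2)n(/C(N)=N/S(=O)(=O)c2cc(C)c(Cl)cc2SCc2ccc(C(F)(F)F)cc2)n1`, gives 16000 nM in a functional assay on MCF7 cells (Homo sapiens) for cytotoxicity, read by MTT assay, with a stated time of 72 h; a lower number here means a stronger inhibitor, a higher number a weaker inhibitor;
compound 2, `Cc1cccc(CSc2cc(Cl)c(C)cc2S(=O)(=O)/N=C(\N)n2nc(C)cc2-c2ccccc2)c1`, gives 105000 nM;
compound 3, `Cc1cc(S(=O)(=O)/N=C(\N)n2nccc2-c2ccccc2)c(SCc2ccc(C(F)(F)F)cc2)cc1Cl`, gives 25000 nM.

Compound 1 and compound 2 differ in the group on the sulfur-bound chain carbon, and this change brought a 6.6-fold higher number from compound 1 to compound 2 (0.82 log units; beyond the scatter). Compound 1 and compound 3 differ in hydrogen in place of methyl on an aromatic carbon, a change that brought a 1.6-fold higher number from compound 1 to compound 3 (0.19 log units; within the scatter). Of the three, compound 2 has the highest number, beyond the scatter from both compound 3 and compound 1.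

Compound 4, `Cc1cc(-c2ccccc2)n(/C(N)=N/S(=O)(=O)c2cc(C)c(Cl)cc2SCc2ccccc2)n1`, has not yet been measured in this assay. It differs from compound 2 in hydrogen in place of methyl on an aromatic carbon. Among the measured compounds shown here, this is the same kind of change as the one from compound 1 to compound 3, but not the same: there the methyl sat on an aromatic carbon of a five-membered aromatic ring with 2 nitrogen, next to the ring nitrogen; here it sits on an aromatic carbon of a six-membered aromatic ring of carbon only, meta to a large group. The cores of the two pairs also differ, by 3-methylphenyl in place of 4-(trifluoromethyl)phenyl on a saturated chain carbon bound to a sulfur.

Because a 1.6-fold higher number from compound 1 to compound 3 (0.19 log units; within the scatter) stayed within the scatter, the step from compound 2 to compound 4 is expected to be small as well, about a 1.2-fold higher number from compound 2 to compound 4 (0.09 log units; within the scatter). This expectation rests on a single earlier step made at a different place, so it is held loosely. Compound 4 is therefore estimated at 130000 nM, with a range from 50000 nM to 350000 nM.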

Compound 4, half-maximal inhibitory concentration: 15000 nM
Beside the measured number, compound 4's estimate is 8.7-fold (0.94 log units) above it; measured number outside the range, below it.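

In this assay, going from 3-methylbenzyl to benzyl on the sulfur brought a 7.0-fold lower number from compound 2 to compound 4 (0.85 log units; beyond the scatter), while hydrogen in place of trifluoromethyl on an aromatic carbon brought a 1.1-fold lower number from compound 1 to compound 4 (0.03 log units; within the scatter), a step within the scatter. Hydrogen in place of methyl on an aromatic carbon therefore did not carry one size of step from one core to another, and the two readings disagree beyond what scatter would allow: the same change on two cores in this assay, a 1.6-fold higher number (0.19 log units; within the scatter) from compound 1 to compound 3 and a 7.0-fold lower number (0.85 log units; beyond the scatter) from compound 2 to compound 4, 11-fold (1.04 log units) apart, beyond the scatter of two such steps. This does not show whether the disagreement comes from the core or from the place of the methyl, since the two pairs differ in both, and each reading rests on a single pair of compounds.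

The compounds shown leave open whether compound 2 stands apart for the methyl on its benzyl group alone, or whether a larger group there, such as ethyl or methoxy, would give a similar number. They also leave open how the hydrogen-for-methyl change on the five-membered ring would read on the core of compound 4, which would separate the place of the change from the core carrying it.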